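A few compounds are considered here, and "the series" means these few. Any claim that something is new, unique, unknown or untested is made for them only; others in the source may bear on it.

Four compounds from one series share a core built around an amide; they differ in the group attached to the amide carbonyl carbon and in two other parts of the core. Compound 1 `COc1ccc(C(=O)Nc2ccc(N(C)S(C)(=O)=O)c(OCc3cc(Cl)ccc3Cl)c2)cc1OC` and compound 2 `CN(c1ccc(NC(=O)c2ccc(I)cc2)cc1OCc1cc(Cl)ccc1Cl)S(C)(=O)=O` carry the same core. In a functional assay on SK-BR-3 cells (Homo sapiens) for antiproliferative activity, read by MTT assay, with a stated time of 48 h (on this read-out lower numbers stand for stronger inhibition and higher numbers for weaker inhibition), compound 1 gives 3730 nM, and compound 2 gives 660 nM. The change between them is 4-iodophenyl in place of 3,4-dimethoxyphenyl on a carbonyl carbon, and the step it made was a 5.7-fold lower number from compound 1 to compound 2 (0.75 log units; beyond the scatter). Compound 3 `COc1ccc(C(=O)Nc2ccc(N(C)S(=O)(=O)C(F)(F)F)c(OCc3cc(C)ccc3C)c2)cc1OC` has a core of its own; the difference between the two cores is not broken down here. In this assay compound 3 gives 39300 nM, the highest number of the three measured compounds. Compound 4 `Cc1ccc(C)c(COc2cc(NC(=O)c3ccc(I)cc3)ccc2N(C)S(=O)(=O)C(F)(F)F)c1` is related to compound 3 by 4-iodophenyl in place of 3,4-dimethoxyphenyl on a carbonyl carbon, the same change as from compound 1 to compound 2, made at the same place. Since that earlier step was a 5.7-fold lower number from compound 1 to compound 2 (0.75 log units; beyond the scatter), a step of similar size is expected here, estimated as a 5.6-fold lower number from compound 3 to compound 4 (0.75 log units; beyond the scatter). On this basis compound 4 is expected to give about 7000 nM, with a plausible range from 2500 nM to 20000 nM.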

Compound 4, half-maximal inhibitory concentration: 13500 nM
Beside the measured number, compound 4's estimate is 1.9-fold (0.29 log units) below it, and the stated range covers the measured number.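

In this assay, putting 4-iodophenyl in place of 3,4-dimethoxyphenyl on the carbonyl carbon again lowers the number, giving a 2.9-fold lower number from compound 3 to compound 4 (0.46 log units; beyond the scatter). The change therefore points the same way on both cores, and the two steps do not differ in size by more than repeated measurements could explain: the same change on two cores in this assay, a 5.7-fold lower number (0.75 log units; beyond the scatter) from compound 1 to compound 2 and a 2.9-fold lower number (0.46 log units; beyond the scatter) from compound 3 to compound 4, 1.9-fold (0.29 log units) apart, within the scatter of two such steps. Going by these compounds alone, this supports carrying the change between these two cores, but it rests on only two pairs of compounds, so it does not show that the change would transfer to other cores or explain why it lowers the number.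

Still open, going by these compounds, is what other groups on the carbonyl carbon would do, such as 4-bromophenyl, 4-aminophenyl or a saturated cyclohexyl ring. The compounds shown also leave open how the same change would behave on a core that mixes parts of the two cores, which would help show whether either part affects the size of the step.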